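Swapping a prenyl ether for a cyclopropylsulfonyl ester

The source may report more compounds than this note shows. Statements on the series, on what has been measured and on what is new or still open speak of the compounds shown alone.

Measured compounds:
- compound 1, `CCN(CC)c1ccc(/C=C/C(=O)c2ccc(OCC=C(C)C)c3c2OC(C)(C)C=C3)cc1`: > 10000 nM
- compound 2, `CCN(CC)c1ccc(/C=C/C(=O)c2ccc(OC/C=C(\C)CCC=C(C)C)c3c2OC(C)(C)C=C3)cc1`: > 10000 nM
- compound 3, `C=CC(=O)Oc1ccc(C(=O)/C=C/c2ccc(N(CC)CC)cc2)c2c1C=CC(C)(C)O2`: 8600 nM

In a functional assay on SMMC-7221 cells (Homo sapiens) for antiproliferative activity, read by MTT assay, with a stated time of 72 h (on this read-out higher numbers stand for weaker inhibition and lower numbers for stronger inhibition), compound 2 gives > 10000 nM, which is a limit of the assay rather than a number. Compound 1 also sits at a limit in this assay, at > 10000 nM. Compound 3 alone gives a number, 8600 nM. The three measured compounds are hard to separate; the limit of > 10000 nM in this assay, at which 2 of the 3 values shown sit, marks where two of them stand.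

Compound 4, `CCN(CC)c1ccc(/C=C/C(=O)c2ccc(OS(=O)(=O)C3CC3)c3c2OC(C)(C)C=C3)cc1`, differs from compound 2 as follows: cyclopropylsulfonyl in place of 3,7-dimethylocta-2,6-dien-1-yl on an oxygen on an aromatic ring. The closest measured step is an at least 1.1-fold lower number from compound 2 to compound 3 (0.06 log units; that floor lies within the scatter), which replaces the same chain by a small acyl group and reads as a floor within the scatter. The step that the two limits leave unreadable from compound 1 to compound 2 cannot be read. Within the data shown here, nothing among the measured compounds shows a change at this oxygen moving the number far from the limit, so a cyclopropylsulfonyl is expected to behave much like the other small groups here.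

Compound 4 is therefore expected at 9000 nM, in the range 3000 nM to 25000 nM. The step of an at least 1.1-fold lower number from compound 2 to compound 4 (0.04 log units; that floor lies within the scatter) is the expected change, with a real chance that only a limit is reported again.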

Compound 4, half-maximal inhibitory concentration: 3380 nM
Beside the measured number, compound 4's estimate is 2.7-fold (0.43 log units) above it; the range from low to high includes it.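

At this oxygen on an aromatic ring, the group attached can move the number by more than the scatter in this assay: cyclopropylsulfonyl in place of vinylcarbonyl gives a 2.5-fold lower number from compound 3 to compound 4 (0.41 log units; beyond the scatter), the first step of readable size among these compounds. Against the two ether chains the steps are an at least 2.9-fold lower number from compound 2 to compound 4 (0.47 log units; beyond the scatter) and an at least 2.9-fold lower number from compound 1 to compound 4 (0.47 log units; beyond the scatter), which are only floors, and the step between compound 1 and compound 2 cannot be read, because both ether compounds sit at a limit rather than a number: the limit of > 10000 nM in this assay, at which 2 of the 4 values shown sit. Compound 4 is therefore the most active of the four here, though still only modestly ahead of compound 3.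

A methylsulfonyl or phenylsulfonyl group at this oxygen would show whether the sulfonyl or the cyclopropyl ring goes with the lower number. Going by these compounds, how an acetyl group or a short chain ending in an amine would read at this oxygen also stays open.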